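The compounds below may be only part of what the source reports. "The series", "measured", "known", "first", "only" and "open" are said of these compounds alone.

Series in a functional assay on MCF7 cells (Homo sapiens) for inhibition, read by sulforhodamine B assay; a lower number here means a stronger inhibitor, a higher number a weaker inhibitor:
- compound 1 `O=C1C(Nc2ccccc2F)=CC(=O)c2c1nc1n2[C@H]2OC[C@@H](O)[C@H]2OC1`: > 4000 nM, a limit
- compound 2 `O=C1C(Nc2ccccc2)=CC(=O)c2c1nc1n2[C@H]2OC[C@@H](O)[C@H]2OC1`: > 4000 nM, a limit
- compound 3 `Cc1ccc(NC2=CC(=O)c3c(nc4n3[C@H]3OC[C@@H](O)[C@H]3OC4)C2=O)cc1C`: 4950 nM

Compound 3 alone carries a number. The rest of the series sits at the limit of > 4000 nM in this assay, at which 2 of the 3 values shown sit.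

Compound 4 `O=C1C(Nc2ccc(C(F)(F)F)cc2)=CC(=O)c2c1nc1n2[C@H]2OC[C@@H](O)[C@H]2OC1` has 4-(trifluoromethyl)phenyl in place of 3,4-dimethylphenyl on an amine nitrogen.

The closest measured changes are a step that the limit leaves unreadable from compound 2 to compound 3 and a step that the limit leaves unreadable from compound 1 to compound 3, while a step that the two limits leave unreadable from compound 1 to compound 2 also gives no size. None of them supplies a size to carry over, so no step beyond the scatter is expected in this assay, and no direction is assigned. The estimate corresponds to a 1.2-fold higher number from compound 3 to compound 4 (0.08 log units; within the scatter), an expected step that stays within the scatter. For compound 4 the expected value is 6000 nM, with an estimated range of 3000 nM to 15000 nM.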

Compound 4, half-maximal inhibitory concentration: > 4000 nM
Compound 4: only a limit was reported (the forecaster's own chance of this, stated with the estimate: 55%); the middle value is on the limit's open side.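

In this assay compound 4 gives > 4000 nM, a limit, so its steps from compound 1, compound 2 and compound 3 cannot be read. The compounds shown leave open where compound 1, compound 2 and compound 4 actually lie relative to compound 3.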